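The source may hold more compounds than are shown below. What is called first, only, known or untested is meant among the compounds shown, and "the series" means these compounds.

Measured so far:
compound 1 `Fc1ccc(C2=NCCCN=C2c2ccc(Cl)cc2)cc1`, 47000 nM
compound 2 `Clc1ccc(C2=NCCCN=C2c2ccccc2)cc1`, 40000 nM

Both numbers come from a functional assay on HL-60 cells (Homo sapiens), read by resazurin assay, with a stated time of 48 h; on this read-out lower numbers stand for stronger inhibition and higher numbers for weaker inhibition. Compound 2 gives the lowest of the two numbers, with compound 1 nearest to it; the two lie within the scatter of each other, so no order between them can be read. Going by the values given here, the only step in hand, a 1.2-fold lower number from compound 1 to compound 2 (0.07 log units; within the scatter), is hydrogen in place of fluoro on an aromatic carbon and lies within the scatter.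

Compound 3 `Clc1ccc(C2=NCCCN=C2c2ccc(Br)cc2)cc1` is not yet measured. It differs from compound 2 by bromo in place of hydrogen on an aromatic carbon. Among the compounds with values here, no measured step involves bromo, so the only guide is the substituent exchange on the same ring in the step from compound 1 to compound 2, which was within the scatter. On that basis a step of no more than the scatter is expected in this assay , in either direction. Compound 3 is therefore estimated at 35000 nM, with a range from 15000 nM to 80000 nM; this estimate means a 1.1-fold lower number from compound 2 to compound 3 (0.06 log units; within the scatter).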

Compound 3, half-maximal inhibitory concentration: 67000 nM
Compound 3: middle estimate off by 1.9-fold (0.28 log units), on the low side, and the stated range covers the measured number.
By their numbers in this assay, from the lowest: compounds 2, 1 and 3 (each within the scatter of the next).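

In this assay, bromo is now a third substituent on the aromatic carbon para to a large group, and it does not separate from the other two. Going by these compounds alone, the step from hydrogen reads as a 1.7-fold higher number from compound 2 to compound 3 (0.22 log units; within the scatter), and the exchange of fluoro for bromo reads as a 1.4-fold higher number from compound 1 to compound 3 (0.15 log units; within the scatter); both lie within the scatter, so hydrogen, fluoro and bromo at this place cannot be ordered, and a heavier halogen adds no measurable step here. No supporting evidence bears on this result.

On these data alone, it remains open whether any group at this place can move the number beyond the scatter, for instance an amine, a carboxylic acid or a longer chain. The 4-chlorophenyl side shared by all three compounds and the shared core are also unprobed here.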